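Swapping the Nitrile Ring for a Chloro-Methyl Ring

This account rests on a few compounds, and the source may have more. Where it says the series, first, only, none or still open, it means among the compounds named here.

Compound 3 `N#Cc1ccccc1-c1cccc(COc2ccc(S(=O)(=O)CC(=O)O)cc2)c1` gives 457 nM in a functional assay on CHO cells for agonist activity at Free fatty acid receptor 1 (Homo sapiens), read by FLIPR and calcium flux (a lower number here means that less compound is needed, a higher number that more compound is needed for the effect), the highest of the three measured numbers; compound 2 `O=C(O)CS(=O)(=O)c1ccc(OCc2cccc(-c3ccccc3F)c2)cc1` gives 257 nM, and compound 1 `COc1cc(C)c(-c2cccc(COc3ccc(S(=O)(=O)CC(=O)O)cc3)c2)c(C)c1` gives 57.5 nM. The step of a 1.8-fold higher number from compound 2 to compound 3 (0.25 log units; within the scatter) lies within the scatter, whereas the steps of a 7.9-fold higher number from compound 1 to compound 3 (0.90 log units; beyond the scatter) and a 4.5-fold higher number from compound 1 to compound 2 (0.65 log units; beyond the scatter) show that the group on this aromatic carbon can shift the number well beyond the scatter. Compound 4 `Cc1ccc(-c2cccc(COc3ccc(S(=O)(=O)CC(=O)O)cc3)c2)c(Cl)c1` carries the change (2-chloro-4-methylphenyl in place of 2-cyanophenyl on an aromatic carbon). Within the data shown here, no measured step exchanges a nitrile for a chlorine and a methyl, but compound 1, whose ring also carries methyl groups, has the lowest number of the three. A step of about a 3.0-fold lower number from compound 3 to compound 4 (0.48 log units; beyond the scatter) toward a lower number is therefore expected. Compound 4 is estimated at 150 nM, with a range from 50 nM to 450 nM.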

Compound 4, half-maximal effective concentration in the Free fatty acid receptor 1 assay: 36.3 nM
Estimate against measurement, compound 4: 4.1-fold (0.62 log units) above, and the stated range ends above it.
By their numbers in the Free fatty acid receptor 1 assay, from the lowest: compounds 4 and 1 (each within the scatter of the next); then compounds 2 and 3 (each within the scatter of the next).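

In the Free fatty acid receptor 1 assay, replacing the ring on this aromatic carbon can shift the number, with a large step in a 13-fold lower number from compound 3 to compound 4 (1.10 log units; beyond the scatter) and a modest step in a 7.1-fold lower number from compound 2 to compound 4 (0.85 log units; beyond the scatter). Also in the Free fatty acid receptor 1 assay, a 1.6-fold lower number from compound 1 to compound 4 (0.20 log units; within the scatter), so 2-chloro-4-methylphenyl, which has no methoxy group, matches 4-methoxy-2,6-dimethylphenyl within the scatter. Nothing measured here explains why this ring change matters so much.

In a physicochemical assay for lipophilicity, using the shake flask method, in phosphate buffer, measured as octanol-water partition, with a stated time of 24 h, at pH 7.4, tested at 100 uM (on this read-out higher numbers stand for higher lipophilicity and lower numbers for lower lipophilicity), compound 4 gives 3.05, but compound 3 gives "not determined" (no result reported), so that read-out allows no comparison across this change. As far as these compounds go, it remains open whether the chlorine or the methyl accounts for the shift, and how an amine on this ring would behave.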